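Pyridin-4-yl in place of benzothiazolyl on a shared core

This account rests on a few compounds, and the source may have more. Where it says the series, first, only, none or still open, it means among the compounds named here.

In a functional assay on MDA-MB-231 cells (Homo sapiens) for inhibition, read by CellTiter-Glo, with a stated time of 72 h (a lower number here means that less compound is tolerated, a higher number that more compound is tolerated), compound 1 `CC1=C(CC(=O)NCCN(C)C)c2cc(F)ccc2/C1=C\c1nc2ccccc2s1` gives 3630 nM and sits level with its close relative, compound 2 `CC1=C(CC(=O)N(C)CCN(C)C)c2cc(F)ccc2/C1=C\c1nc2ccccc2s1`, at 3800 nM as its own value. Among the measured compounds shown here, the one measured step between them, a 1.0-fold higher number from compound 1 to compound 2 (0.02 log units; within the scatter) for methyl in place of hydrogen on an amide-type nitrogen, stays within the scatter, and it lies at a different place from the change considered here. Compound 3 `CC1=C(CC(=O)NCCN(C)C)c2cc(F)ccc2/C1=C\c1ccncc1` carries pyridin-4-yl in place of 1,3-benzothiazol-2-yl on a double-bonded chain carbon bound to a double-bonded ring carbon. For the measured compounds named here, no measured step touches that place, so the data offer no size to carry over, and any direction in this assay is a judgement. The anchor remains compound 1 at 3630 nM as measured, and a cautious lean to a higher number is expected. The expected step runs a 1.9-fold higher number from compound 1 to compound 3 (0.29 log units; within the scatter) as a rough guess. For compound 3 the expected value is 7000 nM (range 2000 nM to 25000 nM).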

Compound 3, half-maximal cytotoxic concentration: 18100 nM
For compound 3 the middle estimate is 2.6-fold (0.41 log units) below the measured one; measured number inside the range.
By their numbers in this assay, from the lowest: compounds 1 and 2 (each within the scatter of the next); then compound 3.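

In this assay the group on a double-bonded chain carbon bound to a double-bonded ring carbon proves to matter, with pyridin-4-yl in place of 1,3-benzothiazol-2-yl giving a 5.0-fold higher number from compound 1 to compound 3 (0.70 log units; beyond the scatter) and moving the number beyond the usual scatter. Among the compounds shown here, the earlier step on the amide-type nitrogen, a 1.0-fold higher number from compound 1 to compound 2 (0.02 log units; within the scatter), showed no such separation, so this is the first place on the shared core where a change clearly registers. No supporting measurement accounts for the rise, and this single swap replaces a five-membered and a six-membered aromatic ring with one six-membered aromatic ring, so its parts cannot be told apart.

On these data alone, it remains open whether phenyl or pyridin-2-yl at this place would stand nearer compound 1 or compound 3. Also open, as far as these compounds go, is whether methyl on the amide-type nitrogen would stay within the scatter with pyridin-4-yl present.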